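The source may hold more compounds than are shown below. What is called first, only, known or untested is meant among the compounds shown, and "the series" means these compounds.

Measured so far in an assay on cells for inhibition of histone-lysine N-methyltransferase EZH2 (Homo sapiens), read by ELISA, with a stated time of 72 h; a lower number here means a stronger inhibitor, a higher number a weaker inhibitor:
compound 1 `Cc1cc(C)c(CN2CCc3c(F)cc(O[C@@H]4CCOC4)c(Cl)c3C2=O)c(=O)[nH]1` gives 994 nM
compound 2 `Cc1cc(C)c(CN2CCc3c(Cl)cc(-c4cn[nH]c4)c(Cl)c3C2=O)c(=O)[nH]1` gives 1730 nM
compound 3 `Cc1cc(C)c(CN2CCc3ccc(-c4c(C)noc4C)c(Cl)c3C2=O)c(=O)[nH]1` gives 105 nM

Compound 2 gives the highest of the three numbers in this assay; compound 1 sits within the scatter of it, while compound 3 gives a clearly lower number. Compound 4 `Cc1cc(C)c(CN2CCc3c(Cl)cc(-c4c(C)n[nH]c4C)c(Cl)c3C2=O)c(=O)[nH]1` has not yet been measured. Relative to compound 2 it carries 3,5-dimethyl-1H-pyrazol-4-yl in place of 1H-pyrazol-4-yl on an aromatic carbon. Within the data shown here, no step between measured compounds isolates this change, and compound 3 differs from compound 2 in more than one place, so its value cannot be charged to the methyls alone. A modest step to a lower number in this assay is expected, a 2.7-fold lower number from compound 2 to compound 4 (0.43 log units; beyond the scatter), with a range that also allows no change beyond the scatter. Compound 4 is estimated at 650 nM, between 200 nM and 2200 nM.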

Compound 4, half-maximal inhibitory concentration: 502 nM
Compound 4: the middle estimate sits 1.3-fold (0.11 log units) above what was measured, within the range that was stated.
By their numbers in this assay, from the lowest: compound 3; then compounds 4, 1 and 2 (each within the scatter of the next, the first and the last beyond it).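

In this assay, the position on the aromatic carbon ortho to a chloro group responds to substitution on the pyrazole itself: 3,5-dimethyl-1H-pyrazol-4-yl in place of 1H-pyrazol-4-yl gives a 3.4-fold lower number from compound 2 to compound 4 (0.54 log units; beyond the scatter) and is the only single-place step shown at this position. The ring type and the donor and acceptor counts stay the same across this change, so the step goes with the two added methyl groups. No measurement here explains why the number falls. Still open, from the compounds shown here alone, is whether a single methyl group gives the same step, and whether ethyl or trifluoromethyl groups in place of the two methyl groups extend or reverse it.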